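Amine substituent changes on the enedione carbon of the core

This account rests on a few compounds, and the source may have more. Where it says the series, first, only, none or still open, it means among the compounds named here.

Measured so far:
compound 1, `COc1cccc(NC2=CC(=O)c3c(nc4n3[C@H]3OC[C@@H](O)[C@H]3OC4)C2=O)c1`
compound 2, `O=C1C=C(NC2CCCC2)C(=O)c2c1nc1n2[C@H]2OC[C@@H](O)[C@H]2OC1`
compound 3, `COc1ccc(NC2=CC(=O)c3nc4n(c3C2=O)[C@H]2OC[C@@H](O)[C@H]2OC4)cc1`

In a functional assay on HeLa cells (Homo sapiens) for inhibition, read by sulforhodamine B assay (a higher number here means a weaker inhibitor, a lower number a stronger inhibitor), compound 1 gives > 8000 nM, which is a limit of the assay and not a number. Compound 2 gives > 16000 nM, likewise a limit. Among the measured compounds shown here, compound 3 gives 4780 nM, the only numbered value in the set. For the measured compounds named here, the single step between neighbours that differ in one place is an at least 3.3-fold lower number from compound 2 to compound 3 (0.52 log units; beyond the scatter), aryl amine over cycloalkyl amine. Going by the values given here, compound 1 therefore stands at a limit, with compound 2 at the other limit and compound 3 the sole measured number.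

Compound 4, `CCCN(CCC)C1=CC(=O)c2c(nc3n2[C@H]2OC[C@@H](O)[C@H]2OC3)C1=O`, is not yet measured. dipropylamino in place of (3-methoxyphenyl)amino on a double-bonded ring carbon The change runs from an arylamine to a dialkylamine, the reverse direction of an at least 3.3-fold lower number from compound 2 to compound 3 (0.52 log units; beyond the scatter), where the alkyl amine sat at a limit and the aryl amine gave a number. The expectation is therefore a higher number or again a limit. Compound 4 is expected near 20000 nM, with a range from 8000 nM to 60000 nM. That estimate corresponds to a step that the limit leaves unreadable from compound 1 to compound 4, most likely reported only as a limit.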

Compound 4, half-maximal inhibitory concentration: > 16000 nM
Compound 4: only a limit was reported; the forecaster's own chance of this, stated with the estimate: 85%; the middle value is on the limit's open side.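

In this assay compound 4 gives > 16000 nM, a limit and not a number. Among the compounds shown here, compound 1 also stands at a limit, so no step between compound 1 and compound 4 can be read. The compounds shown leave open how large the effect of exchanging (3-methoxyphenyl)amino for dipropylamino actually is.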